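A rearranged ring group and solubility at the limit

The source may hold more compounds than are shown below. What is called first, only, known or untested is meant among the compounds shown, and "the series" means these compounds.

- compound 1 `N#Cc1ccc(NC2CCC(N(C(=O)NCc3ccccc3)c3ccccc3)CC2)nc1` gives 4 ug/mL
- compound 2 `Cn1c(-c2ccc(N(C(=O)NCc3ccccc3)C3CCC(Nc4ccc(C#N)cn4)CC3)cc2)cccc1=O` gives < 0.09 ug/mL, which is a limit and not a number

Both values come from a physicochemical assay for solubility, at pH 6.8; on this read-out higher numbers stand for higher solubility and lower numbers for lower solubility. Compound 2 sits at the limit of < 0.09 ug/mL in this assay, at which 1 of the 2 values shown sits, and so has no exact number.

Compound 3 `Cn1ccc(-c2ccc(N(C(=O)NCc3ccccc3)C3CCC(Nc4ccc(C#N)cn4)CC3)cc2)cc1=O` has the same atoms as compound 2, joined differently: a group of 8 heavy atoms (6 carbon, 1 nitrogen, 1 oxygen; one six-membered aromatic ring with 1 hetero atom) in place of a group of 8 heavy atoms (6 carbon, 1 nitrogen, 1 oxygen; one six-membered aromatic ring with 1 hetero atom), on an aromatic carbon. The group sits on an aromatic carbon of a six-membered aromatic ring of carbon only, para to a large group.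

Within the data shown here, the one measured step that bears on this is large: an at least 44-fold lower number from compound 1 to compound 2 (1.64 log units; beyond the scatter). That step put the group in place of a hydrogen atom, whereas here one such group replaces another, so its size does not carry over. Compound 3 keeps a group of this size, so it is expected to stay far from compound 1 (4 ug/mL) and close to compound 2.

The estimated step is an at least 1.6-fold higher number from compound 2 to compound 3 (0.22 log units; that floor lies within the scatter), so no large move is expected in this assay. Compound 3 is estimated at 0.15 ug/mL, within a range of 0.05 ug/mL to 1 ug/mL.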

Compound 3, solubility: < 0.08 ug/mL
Compound 3: no number, only a limit; the forecaster's own chance of this, stated with the estimate: 55%; middle value at least 1.8-fold (0.27 log units) from the limit.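

In this assay, the rearranged group also gives an at least 50-fold lower number from compound 1 to compound 3 (1.69 log units; beyond the scatter), so a second way of joining these same atoms, at the same place para to a large group, also leaves the compound far under compound 1. Compound 3 gives a limit and not a number: the limit of < 0.08 ug/mL in this assay, at which 1 of the 3 values shown sits. With compound 2 also at a limit, the step between these two cannot be read, so the data show no order between the two arrangements.

From the compounds shown here alone, how far under their limits compound 2 and compound 3 lie stays open. Also open, going by these compounds, is whether a smaller group such as methoxy, or a ring group carrying an amine or a carboxylic acid, at this place would bring the read-out back near that of compound 1, which gives 4 ug/mL.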